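Fluoro for bromo on the outer phenyl ring

The source may report more compounds than this note shows. Statements on the series, on what has been measured and on what is new or still open speak of the compounds shown alone.

Among the measured compounds shown here, compound 2 `O=C1COc2ccc(-c3nn(-c4ccc(Br)cc4)cc3-c3ccccc3)cc2N1` gives 54.2% in a functional assay on DLD-1 cells (Homo sapiens) for cytotoxicity, read by colorimetric assay and MTT assay, with a stated time of 3 days, tested at 20 uM (on this read-out lower numbers stand for a stronger effect and higher numbers for a weaker effect at the one concentration tested), the highest of the two numbers so far; compound 1 `COc1ccc(-n2cc(-c3ccccc3)c(-c3ccc4c(c3)NC(=O)CO4)n2)cc1` gives 35.6%. For the measured compounds named here, the only step at hand, a number 18.6 percentage points higher from compound 1 to compound 2 (beyond the scatter), exchanges a different group at the same aromatic carbon and bears only loosely on the present change. Compound 3 `O=C1COc2ccc(-c3nn(-c4ccc(F)cc4)cc3-c3ccccc3)cc2N1` differs from compound 2 by fluoro in place of bromo on an aromatic carbon. Without a halogen-for-halogen comparison, no step beyond the scatter is expected, so for compound 3 a value of 47% (range 28% to 68%) is estimated, a change of a number 7.2 percentage points lower from compound 2 to compound 3 (within the scatter).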

Compound 3, a percentage reported as activity, at one concentration (the size of the read-out at that concentration, not a potency): 45.2%
Compound 3: the middle estimate sits 1.8 percentage points above what was measured; the measured number falls inside the stated range.
By their numbers in this assay, from the lowest: compounds 1, 3 and 2 (each within the scatter of the next, the first and the last beyond it).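

The exchange of 4-bromophenyl for 4-fluorophenyl in this assay comes to a number 9 percentage points lower from compound 2 to compound 3 (within the scatter), so the two halogens cannot be told apart at this carbon. Fluoro also cannot be separated from methoxy at the same place, with a number 9.6 percentage points higher from compound 1 to compound 3 (within the scatter), whereas bromo alone stood clear of methoxy. Nothing measured here explains these numbers.

Still open, going by these compounds, is whether an amine or a carboxylic acid on this aromatic carbon would shift the read-out beyond the scatter. On these data alone, it is also open how the plain phenyl ring, with hydrogen at this place, would compare.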